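This account rests on a few compounds, and the source may have more. Where it says the series, first, only, none or still open, it means among the compounds named here.

Measured compounds:
Compound 1 `C[C@@H](Nc1nc(Cl)nc(NC(C)(C)C)n1)c1ccccc1`: 9330 nM
Compound 2 `CC[C@H](C)Nc1nc(Cl)nc(N[C@@H](C)c2ccccc2)n1`: 6920 nM
Compound 3 `CC(C)Nc1nc(Cl)nc(N[C@H](C)c2ccccc2)n1`: 5370 nM

All three compounds share one core and were tested in an ADME assay on the whole organism for inhibition, with Oryza sativa as the target, with a stated time of 4 days; on this read-out higher numbers stand for weaker inhibition and lower numbers for stronger inhibition. Compound 2 sits second highest of the three numbers; compound 3 is nearest and compound 1 furthest, and both gaps lie within the scatter, so the three values cannot be told apart with confidence. Going by the values given here, the only step between compounds that differ in a single place is a 1.7-fold lower number from compound 1 to compound 3 (0.24 log units; within the scatter), and it too stays within the scatter.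

Compound 4 `CC(C)N(c1nc(Cl)nc(N[C@@H](C)c2ccccc2)n1)C(C)C` is the unmeasured partner of compound 2. The change is diisopropylamino in place of (sec-butyl)amino on an aromatic carbon. Among the compounds with values here, no measured step swaps one group attached to an aromatic carbon of the core for another; the single step on record changes a methyl for hydrogen on a saturated chain carbon, and its size is within the scatter. The data therefore give no direct guide to the direction of this change, and only a modest, uncertain step is expected, with a wide range around it.

Compound 4 is estimated at 12000 nM in this assay, with a range from 3000 nM to 50000 nM, which would mean an expected step of a 1.7-fold higher number from compound 2 to compound 4 (0.24 log units; within the scatter).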

Compound 4, half-maximal inhibitory concentration: 372 nM
The estimate for compound 4 lay 32-fold (1.51 log units) above the measured number, outside the stated range (below it).
By their numbers in this assay, from the lowest: compound 4; then compounds 3, 2 and 1 (each within the scatter of the next).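

Going by these compounds alone, on the aromatic carbon between two ring nitrogen atoms, opposite the ring nitrogen, replacing (sec-butyl)amino with diisopropylamino gives a 19-fold lower number from compound 2 to compound 4 (1.27 log units; beyond the scatter) in this assay, the first step in this set that lies beyond the scatter, so this position can clearly change the read-out. The change also bundles several differences: the group goes from 5 to 7 heavy atoms, from 1 hydrogen-bond donor to 0, and loses its 1 defined stereocentre, and this single step cannot separate them. Nothing measured here accounts for the size of the step.

From the compounds shown here alone, it remains open whether the lower number depends on having two chains on this nitrogen, on the loss of its hydrogen, or on the branching of the isopropyl groups, and comparing diethylamino, N-methyl-sec-butylamino or a piperidine ring at the same position could begin to separate these possibilities. Going by these compounds, it is equally open whether the effect of diisopropylamino would hold if a methoxy group replaced the chloro group on the shared core.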